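Vinyl in Place of Prop-1-en-1-yl on a Carbonyl Carbon

This account rests on a few compounds, and the source may have more. Where it says the series, first, only, none or still open, it means among the compounds named here.

Of the compounds shown here, three have been tested in a functional assay on Maver1 cells (Homo sapiens) for inhibition, read by luminescence and CellTiter-Glo, with a stated time of 72 h; on this read-out higher numbers stand for weaker inhibition and lower numbers for stronger inhibition. Compound 1 `C=CC(=O)Nc1ccc(Cn2nc(-c3ccc(Oc4ccccc4)cc3)cc2C(=O)O)cc1` reaches only the limit of > 60000 nM. Compound 2 `C/C=C/C(=O)Nc1ccc(Cn2nc(-c3ccc(Oc4ccccc4)cc3)cc2C(=O)O)cc1` likewise reaches only the limit of > 60000 nM. Within the data shown here, compound 3 `C/C=C/C(=O)Nc1cccc(Cn2nc(-c3ccc(Oc4ccccc4)cc3)cc2C(=O)OCC)c1` gives 14200 nM, the only number among the three. The change from compound 2 to compound 1, (vinyl in place of prop-1-en-1-yl on a carbonyl carbon), gives a step that the two limits leave unreadable from compound 2 to compound 1 because of the limit of > 60000 nM in this assay, at which 2 of the 3 values shown sit. How the cores of compound 2 and compound 3 differ is not broken down here. Among the measured compounds shown here, compound 4 `C=CC(=O)Nc1cccc(Cn2nc(-c3ccc(Oc4ccccc4)cc3)cc2C(=O)OCC)c1` is still to be measured in this assay; it differs from compound 3 by vinyl in place of prop-1-en-1-yl on a carbonyl carbon, the same change as the one made from compound 2 to compound 1. The step is estimated at a 1.6-fold lower number from compound 3 to compound 4 (0.20 log units; within the scatter), resting only on compound 3 at 14200 nM, since the earlier step shows nothing readable. Compound 4 is expected to give about 9000 nM, lying between 3000 nM and 30000 nM.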

Compound 4, half-maximal inhibitory concentration: 8600 nM
Beside the measured number, compound 4's estimate is 1.0-fold (0.02 log units) above it; the range from low to high includes it.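

In this assay, vinyl in place of prop-1-en-1-yl on a carbonyl carbon gives a 1.7-fold lower number from compound 3 to compound 4 (0.22 log units; within the scatter), so on the core of compound 3 this change has no effect that can be told from the scatter. Among these compounds, the same change on the core of compound 2 cannot be read, because neither that compound nor compound 1 gives a number: the limit of > 60000 nM in this assay, at which 2 of the 4 values shown sit. The two cores therefore offer no pair of steps to compare, so the result neither confirms nor rules out that the change carries over from one to the other.

Still open, going by these compounds, is whether a longer chain or an amine in place of vinyl on that carbonyl carbon would move the number beyond the scatter.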